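The source may hold more compounds than are shown below. What is called first, only, known or untested is meant among the compounds shown, and "the series" means these compounds.

In a functional assay on DU-145 cells (Homo sapiens) for cytotoxicity, read by MTT assay (on this read-out higher numbers stand for weaker inhibition and lower numbers for stronger inhibition), three compounds built on a shared core have been measured so far. Compound 1 `COc1ccc2cc([C@H](C)c3nnc(SCc4ccc(Cl)cc4)n3-c3ccc(F)cc3)ccc2c1` gives 57400 nM. Compound 3 `COc1ccc2cc([C@H](C)c3nnc(SCc4c(C)cc(C)cc4C)n3-c3ccc(F)cc3)ccc2c1` gives 10200 nM, the lower of the two actual numbers, so it is the stronger inhibitor of this pair. Compound 2 `COc1cccc(CSc2nnc([C@@H](C)c3ccc4cc(OC)ccc4c3)n2-c2ccc(Cl)cc2)c1` gives <= 400000 nM, which is a limit of the assay and not a number.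

Compound 4 `COc1cccc(CSc2nnc([C@@H](C)c3ccc4cc(OC)ccc4c3)n2-c2ccc(F)cc2)c1` differs from compound 3 in one place, on a saturated chain carbon bound to a sulfur, where 3-methoxyphenyl stands in place of 2,4,6-trimethylphenyl (3-methoxyphenyl in place of 2,4,6-trimethylphenyl on a saturated chain carbon bound to a sulfur). Among the measured compounds shown here, only one measured step changes this place: a 5.6-fold lower number from compound 1 to compound 3 (0.75 log units; beyond the scatter), when 2,4,6-trimethylphenyl replaced 4-chlorophenyl. Compound 2 also carries 3-methoxyphenyl here, but its limit offers no number to work from.

For the measured compounds named here, removing 2,4,6-trimethylphenyl reversed no measured step, so the guide is thin. Still, the modest gain seen on reaching compound 3 suggests that losing this group should give back a similar amount, moving towards a higher number and weaker inhibition. That expected change is a 3.9-fold higher number from compound 3 to compound 4 (0.59 log units; beyond the scatter). Compound 4 is therefore estimated at about 40000 nM, with an expected range from 12000 nM to 150000 nM.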

Compound 4, half-maximal inhibitory concentration: 19200 nM
The estimate for compound 4 lay 2.1-fold (0.32 log units) above the measured number; the measured number falls inside the stated range.
By their numbers in this assay, from the lowest: compounds 3 and 4 (each within the scatter of the next); then compound 1.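

In this assay there is a 1.9-fold higher number from compound 3 to compound 4 (0.27 log units; within the scatter), so on a saturated chain carbon bound to a sulfur, these two groups cannot be told apart, even though 3-methoxyphenyl brings an oxygen and one hydrogen-bond acceptor that 2,4,6-trimethylphenyl lacks. The comparison with 4-chlorophenyl gives a 3.0-fold lower number from compound 1 to compound 4 (0.48 log units; beyond the scatter), which means that a second, quite different group now gives a lower number than 4-chlorophenyl, so the earlier drop at this place no longer rests on 2,4,6-trimethylphenyl alone. The step that swaps fluoro for chloro on an aromatic carbon, linking compound 2 with compound 4, cannot be read, because the value of compound 2 is a limit of the assay and not a number: the limit of <= 400000 nM in this assay, at which 1 of the 4 values shown sits.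

Among the compounds shown here, with only three readable numbers, it remains open whether a benzyl group carrying an amine or a carboxylic acid would give a number close to those of compound 3 and compound 4 or closer to that of compound 1. On these data alone, a longer chain between the sulfur and the aromatic ring is equally open, as is the effect of fluoro in place of chloro on an aromatic carbon.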